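A few compounds are considered here, and "the series" means these few. Any claim that something is new, unique, unknown or untested is made for them only; others in the source may bear on it.

Compound 1 `Cc1ccc(C(=O)N[C@H]2CCN(Cc3ccc(OCCCN(C)C)cc3)C2)cc1C` — in an assay on HEK293 cells for binding affinity to Urotensin-2 receptor (Homo sapiens), read by radioligand binding (a lower number here means a stronger inhibitor, a higher number a weaker inhibitor), compound 1 gives < 10000 nM, a limit of the assay.
Compound 2 `CN(C)CCCOc1ccc(CN2CC[C@H](NC(=O)c3ccncc3)C2)cc1` — in this assay compound 2 gives < 10000 nM, likewise a limit.
Compound 3 `CC(C)C[C@H](NC(=O)c1ccc(Cl)c(Cl)c1)C(=O)N[C@H]1CCN(Cc2ccc(OCCCN(C)C)cc2)C1` — in this assay compound 3 gives 126 nM.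

Among the measured compounds shown here, compound 3 carries the only number among the three; the other two sit at the limit of < 10000 nM in this assay, at which 2 of the 3 values shown sit. For the measured compounds named here, the single measured step, a step that the two limits leave unreadable from compound 1 to compound 2, is hidden by those limits and gives no size. Compound 4 `CC(C)C[C@H](NC(=O)Nc1ccccc1)C(=O)N[C@H]1CCN(Cc2ccc(OCCCN(C)C)cc2)C1` differs from compound 3 by anilino in place of 3,4-dichlorophenyl on a carbonyl carbon. Going by the values given here, no measured step covers this change; what is known is only that compound 3, with the dichlorophenyl carbonyl, reaches a number where compounds 1 and 2 do not. Exchanging that group for a phenylcarbamoyl is expected to weaken binding, the estimated step being a 4.8-fold higher number from compound 3 to compound 4 (0.68 log units; beyond the scatter). Compound 4 is therefore expected at 600 nM, within 150 nM to 3000 nM.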

Compound 4, inhibition constant: 1000 nM
Beside the measured number, compound 4's estimate is 1.7-fold (0.22 log units) below it; low and high end bracket the measured number.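

In this assay, the change on this carbonyl carbon now has a readable size, anilino in place of 3,4-dichlorophenyl giving a 7.9-fold higher number from compound 3 to compound 4 (0.90 log units; beyond the scatter), and compound 4 still gives a number rather than a limit. Nothing measured here accounts for the size of this step. The step from compound 1 to compound 2 cannot be read: the limit of < 10000 nM in this assay, at which 2 of the 4 values shown sit.

On these data alone, whether the change in number follows from the loss of the two chlorines or from the entry of the anilino hydrogen remains open. A plain phenyl or a 4-chlorophenyl on this carbonyl carbon would separate the two.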